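The source may hold more compounds than are shown below. What is called first, only, known or untested is meant among the compounds shown, and "the series" means these compounds.

Measured compounds:
- compound 1, `NS(=O)(=O)c1ccc(N2N=C(c3ccc(Oc4ccccc4)cc3)CC2c2ccc(Cl)cc2)cc1` — 9000 nM
- compound 2, `NS(=O)(=O)c1ccc(N2N=C(c3ccc(OCc4ccccc4)cc3)CC2c2ccccc2)cc1` — > 100000 nM
- compound 3, `NS(=O)(=O)c1ccc(N2N=C(c3ccc(Oc4ccccc4)cc3)CC2c2ccccc2Cl)cc1` — 40000 nM

In an ADME assay on MT4 cells (Homo sapiens) for cytotoxicity, read by MTT assay, with a stated time of 96 h (a lower number here means that less compound is tolerated, a higher number that more compound is tolerated), compound 3 holds the higher of the two numbers that were read. Its nearest neighbour is compound 1, and the step of a 4.4-fold higher number from compound 1 to compound 3 (0.65 log units; beyond the scatter) is modest but lies beyond the scatter, so compound 3 is tolerated somewhat better than compound 1. Among the compounds with values here, compound 2 does not give a number at all: its result in this assay is a limit, (the limit of > 100000 nM in this assay, at which 1 of the 3 values shown sits), so it is known only that compound 2 sits there or beyond.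

The next compound, compound 4, `NS(=O)(=O)c1ccc(N2N=C(c3ccc(Oc4ccccc4)cc3)CC2c2ccccc2)cc1`, differs from compound 3 by hydrogen in place of chloro on an aromatic carbon. Within the data shown here, none of the measured steps removes a chloro group; the one measured step, a 4.4-fold higher number from compound 1 to compound 3 (0.65 log units; beyond the scatter), only moves the chloro from one ring position to another, and the shared core is otherwise unchanged. Compound 2, which also carries a plain phenyl on the saturated ring carbon, gives only a limit and cannot fix the size of the step. The expectation is therefore loose: a step of a 1.5-fold higher number from compound 3 to compound 4 (0.18 log units; within the scatter) is estimated, with the chance that compound 4 also reaches the limit. Compound 4 is expected to give 60000 nM, with a range from 20000 nM to 150000 nM.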

Compound 4, half-maximal cytotoxic concentration: 42000 nM
Compound 4: middle estimate off by 1.4-fold (0.15 log units), on the high side; low and high end bracket the measured number.
By their numbers in this assay, from the lowest: compound 1; then compounds 3 and 4 (each within the scatter of the next). At a limit, above all of these: compound 2.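

The step of a 1.1-fold higher number from compound 3 to compound 4 (0.02 log units; within the scatter) shows that in this assay the 2-chlorophenyl and the plain phenyl on the saturated ring carbon cannot be told apart, so chloro at this position leaves the number where it stands. The same exchange of chloro for hydrogen starting from the 4-chlorophenyl does register, as the step of a 4.7-fold higher number from compound 1 to compound 4 (0.67 log units; beyond the scatter) shows, which leaves compound 1 as the only one of the three phenoxy compounds with a clearly lower number, and the effect of chloro here depends on where it sits on the ring. A separate change on the oxygen, phenyl in place of benzyl, gives the step of an at least 2.3-fold lower number from compound 2 to compound 4 (0.37 log units; beyond the scatter) and can be read only in one direction, since compound 2 stands at a limit of the assay: the limit of > 100000 nM in this assay, at which 1 of the 4 values shown sits.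

Going by these compounds, whether a fluoro, a methoxy or an amine on that same phenyl would follow the 2-chlorophenyl or the 4-chlorophenyl stays open. On these data alone, the full size of the benzyl step also stays open, and so does whether the 4-chlorophenyl would lower the number on the benzyl compound too.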